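The source may hold more compounds than are shown below. What is called first, only, known or untested is meant among the compounds shown, and "the series" means these compounds.

Measured so far in a functional assay on PC-3 cells (Homo sapiens) for antiproliferative activity, read by MTT assay, with a stated time of 48 h; on this read-out higher numbers stand for weaker inhibition and lower numbers for stronger inhibition:

Compound 1 `CC1(C)Cc2c(ccc(C(=O)/C=C/c3ccccc3)c2OCc2ccccc2)O1` gives > 100000 nM, which is a limit of the assay, not a number.

Compound 2 `CC1(C)Cc2c(ccc(C(=O)/C=C/c3cn(-c4ccccc4)nc3-c3cccc([N+](=O)[O-])c3)c2OCc2ccccc2)O1` gives > 100000 nM, again a limit of the assay and not a number.

Where compound 2 stands: only a limit is known for it, and the one other value shown is also a limit (the limit of > 100000 nM in this assay, at which 2 of the 2 values shown sit). Among the compounds with values here, no step between measured compounds can be stated, since compound 1 and compound 2 differ in more than one place and both sit at the limit; their two values show only that neither reached a measurable inhibition in this assay.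

The next compound, compound 3 `COc1ccc(-c2nn(-c3ccccc3)cc2/C=C/C(=O)c2ccc3c(c2OCc2ccccc2)CC(C)(C)O3)cc1`, differs from compound 2 in a single place: 4-methoxyphenyl in place of 3-nitrophenyl on an aromatic carbon.

With both shown values at the limit, there is no measured step on which to build an expectation of a shift in either direction. The expected change from compound 2 to compound 3 in this assay is therefore none beyond the scatter, a number no higher from compound 2 to compound 3 (the limit leaves the size open). For compound 3 the estimate in this assay is 100000 nM, with a range of 30000 nM to 300000 nM, and it is expected that the assay will most likely again report only a limit.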

Compound 3, half-maximal inhibitory concentration: 18400 nM
Compound 3: the middle estimate sits 5.4-fold (0.74 log units) above what was measured, and the stated range ends above it.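

In this assay, 4-methoxyphenyl in place of 3-nitrophenyl gives an at least 5.4-fold lower number from compound 2 to compound 3 (0.73 log units; beyond the scatter), and compound 3 is the first of the compounds shown with a measured value, 18400 nM. The position on the aromatic carbon of the five-membered aromatic ring with 2 nitrogen, next to the ring nitrogen, therefore responds to the group it carries, at least for this one pair, which the two earlier values could not show. Compound 2 has only a limit of the assay and not a number, so the step gives a lower bound on the change and its true size stays open: the limit of > 100000 nM in this assay, at which 2 of the 3 values shown sit.

The compounds shown do not separate the loss of the nitro group from the gain of the methoxy group, so either could account for the step. A plain phenyl at this position, or a phenyl carrying an amine or a carboxylic acid, would help to show which of the two matters and how far the change in this assay can go.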